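The source may hold more compounds than are shown below. What is called first, only, known or untested is meant among the compounds shown, and "the series" means these compounds.

In a functional assay on HL-60 cells (Homo sapiens) for antiproliferative activity, read by MTT assay, with a stated time of 48 h (on this read-out lower numbers stand for stronger inhibition and higher numbers for weaker inhibition), three compounds sharing one core have been measured. Compound 1 `Cn1c(N)c(-c2nc3ccccc3[nH]2)c2nc(C#N)c(C#N)nc21` gives > 50000 nM, which is a limit of the assay and not a number. Compound 2 `CN(C)CCn1c(N)c(-c2nc3ccccc3[nH]2)c2nc(C#N)c(C#N)nc21` gives 2220 nM, and compound 3 `CN(C)CCCn1c(N)c(-c2nc3ccccc3[nH]2)c2nc(C#N)c(C#N)nc21` gives 870 nM, the lower of the two actual numbers. Large steps came with the amine chains, an at least 22-fold lower number from compound 1 to compound 2 (1.35 log units; beyond the scatter) and an at least 57-fold lower number from compound 1 to compound 3 (1.75 log units; beyond the scatter), and the longer chain added a modest one, a 2.6-fold lower number from compound 2 to compound 3 (0.41 log units; beyond the scatter).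

Compound 4 `CCN(CC)CCCn1c(N)c(-c2nc3ccccc3[nH]2)c2nc(C#N)c(C#N)nc21` differs from compound 3 in one place: diethylamino in place of dimethylamino on a saturated chain carbon, three bonds along the chain from an aromatic nitrogen. It carries diethylamino in place of dimethylamino on a saturated chain carbon, three bonds along the chain from an aromatic nitrogen. Going by the values given here, none of the measured steps swaps dimethylamino for another group, so they bear on this change only indirectly. The smallest of them, a 2.6-fold lower number from compound 2 to compound 3 (0.41 log units; beyond the scatter), suggests a step no larger than modest, with neither direction favoured and quite possibly none beyond the scatter. The expected change is a 1.1-fold lower number from compound 3 to compound 4 (0.04 log units; within the scatter). For compound 4 the estimate is 800 nM, with an expected range of 350 nM to 1900 nM.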

Compound 4, half-maximal inhibitory concentration: > 730 nM
Compound 4: no number, only a limit (the forecaster's own chance of this, stated with the estimate: 2%); the middle value is on the limit's open side.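

In this assay compound 4 gives > 730 nM, which is a limit of the assay and not a number. The steps from compound 1, compound 2 and compound 3 to compound 4 therefore cannot be read. The compounds shown leave open whether diethylamino in place of dimethylamino changes the number at all, and in which direction.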